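Benzoyl replaces the hydroxylated chain on the ring nitrogen

The compounds below may be only part of what the source reports. "The series", "measured", "known", "first", "only" and "open" are said of these compounds alone.

Going by the values given here, compound 2 `OC(Cc1ccccc1)CN1CCC(NCCSC(c2ccc(F)cc2)c2ccc(F)cc2)CC1` holds the lowest number of the two measured so far: in an assay on membranes from striatum (strain Sprague-Dawley) for displacement of a labelled ligand from sodium-dependent dopamine transporter (Rattus norvegicus), read by scintillation counting, with a stated time of 120 min (on this read-out lower numbers stand for stronger inhibition and higher numbers for weaker inhibition), compound 2 gives 31.4 nM. Its nearest neighbour, compound 1 `Fc1ccc(C(SCCNC2CCN(Cc3ccc(C(F)(F)F)cc3)CC2)c2ccc(F)cc2)cc1`, gives 190 nM in this assay, and the step of a 6.1-fold lower number from compound 1 to compound 2 (0.78 log units; beyond the scatter) came from putting 1-hydroxy-2-phenylethyl in place of 4-(trifluoromethyl)phenyl on a saturated chain carbon bound to an amine nitrogen in a ring. Compound 3 `O=C(c1ccccc1)N1CCC(NCCSC(c2ccc(F)cc2)c2ccc(F)cc2)CC1` is not yet measured; it differs from compound 2 by benzoyl in place of 2-hydroxy-3-phenylpropyl on an amine nitrogen in a ring. Among the compounds with values here, the one measured step that touches the same nitrogen is that from compound 1 to compound 2, where the group carrying a hydroxyl gave the lower number; compound 3 loses that hydroxyl and carries benzoyl instead. On this slender basis the number for compound 3 is expected to rise, by about an 8.0-fold higher number from compound 2 to compound 3 (0.90 log units; beyond the scatter). Compound 3 is therefore estimated at 250 nM, within 60 nM to 1200 nM.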

Compound 3, inhibition constant: 4.51 nM
Beside the measured number, compound 3's estimate is 55-fold (1.74 log units) above it; measured number outside the range, below it.
By their numbers in this assay, from the lowest: compound 3; then compound 2; then compound 1.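

At this amine nitrogen in a ring, the hydroxyl-bearing chain of compound 2 proves not to be required for a low number in this assay: benzoyl, which has no hydrogen-bond donor, gives a 7.0-fold lower number from compound 2 to compound 3 (0.84 log units; beyond the scatter). The change from 4-(trifluoromethyl)benzyl is larger, with a 42-fold lower number from compound 1 to compound 3 (1.62 log units; beyond the scatter), which leaves compound 3 the strongest of the three. The position therefore accepts a ring joined through a carbonyl as well as through a saturated chain carbon, but no evidence is available to explain these differences.

Going by these compounds, it remains open whether the carbonyl itself matters, a question that an unsubstituted benzyl group on this nitrogen would address. Also open, on these data alone, is how a benzoyl group bearing a fluorine on its ring, or an acetyl group with no ring at all, would read here.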